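Closing a Diethylamino Group into a Piperidine Ring

A few compounds are considered here, and "the series" means these few. Any claim that something is new, unique, unknown or untested is made for them only; others in the source may bear on it.

Compound 2 `CCN(CC)Cc1c(OC)cc(OC)c(C(=O)/C=C/c2ccccc2Cl)c1O` has the highest number of the two measured in a functional assay on HL-60 cells (Homo sapiens) for antiproliferative activity, with a stated time of 72 h (on this read-out lower numbers stand for stronger inhibition and higher numbers for weaker inhibition), giving 30900 nM. Within the data shown here, its nearest neighbour, compound 1 `COc1cc(OC)c(C(=O)/C=C/c2ccccc2Cl)c(O)c1CN(C)CCCN(C)C`, gives 11400 nM; the only measured step, a 2.7-fold higher number from compound 1 to compound 2 (0.43 log units; beyond the scatter), came from exchanging one amine for another at the same place. Compound 3 `COc1cc(OC)c(C(=O)/C=C/c2ccccc2Cl)c(O)c1CN1CCCCC1` differs from compound 2 by piperidin-1-yl in place of diethylamino on a saturated chain carbon bound to an aromatic carbon. That exchange swaps two amines of similar size, so for compound 3 the expected step is a 1.2-fold lower number from compound 2 to compound 3 (0.09 log units; within the scatter), none beyond the scatter. Compound 3 is therefore estimated at 25000 nM, within 8000 nM to 80000 nM.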

Compound 3, half-maximal inhibitory concentration: 3600 nM
Compound 3: middle estimate off by 6.9-fold (0.84 log units), on the high side; the measured number lies below the stated range.
By their numbers in this assay, from the lowest: compound 3; then compound 1; then compound 2.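

Among these compounds, at this position, closing the two ethyl arms of diethylamino into a piperidin-1-yl ring matters: in this assay the change gives an 8.6-fold lower number from compound 2 to compound 3 (0.93 log units; beyond the scatter), the largest step so far. The ring also does better than the longer amine chain of compound 1, with a 3.2-fold lower number from compound 1 to compound 3 (0.50 log units; beyond the scatter), so that chain is not required for a low number here. Nothing available explains why the ring has this effect. As far as these compounds go, it remains open whether the gain is specific to piperidin-1-yl or extends to other cyclic amines, such as pyrrolidin-1-yl or morpholin-4-yl.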